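Notes on naphthyl hydroxypropyl amidrazone series in cytotoxicity

This account rests on a few compounds, and the source may have more. Where it says the series, first, only, none or still open, it means among the compounds named here.

Compound 1 `N/C(CC(O)c1cccc2ccccc12)=N\N=C\c1ccc(F)cc1F` gives 4200 nM in an ADME assay on L6 cells (Rattus norvegicus) for cytotoxicity, read by resazurin assay, with a stated time of 72 h; a higher number here means a weaker inhibitor, a lower number a stronger inhibitor. Compound 2 `N/C(CC(O)c1cccc2ccccc12)=N\N=C\c1ccc(F)cc1` gives 19000 nM in this assay, and the step of a 4.5-fold higher number from compound 1 to compound 2 (0.66 log units; beyond the scatter) corresponds to hydrogen in place of fluoro on an aromatic carbon. Compound 3 `N/C(CC(O)c1ccc2ccccc2c1)=N\N=C\c1ccc(F)cc1F` shares its atoms with compound 1, joined differently; the difference between the two cores is not broken down here. Compound 3 gives 93000 nM in this assay. Compound 4 `N/C(CC(O)c1ccc2ccccc2c1)=N\N=C\c1ccc(F)cc1` is not yet measured; it differs from compound 3 by hydrogen in place of fluoro on an aromatic carbon, the same change as from compound 1 to compound 2. Among the measured compounds shown here, the step from compound 3 to compound 4 is expected to be a 2.7-fold higher number from compound 3 to compound 4 (0.43 log units; beyond the scatter), resting on the one earlier step, a 4.5-fold higher number from compound 1 to compound 2 (0.66 log units; beyond the scatter), carried over to the other core. Compound 4 is therefore estimated at 250000 nM, between 90000 nM and 700000 nM, with a real chance that this assay reports only a limit for compound 4.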

Compound 4, half-maximal inhibitory concentration: > 298000 nM
Compound 4 gave a limit, no number (the forecaster's own chance of this, stated with the estimate: 40%); at least 1.1-fold (0.07 log units) between middle value and limit.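

The change from 2,4-difluorophenyl to 4-fluorophenyl keeps its direction on the second core, an at least 3.2-fold higher number from compound 3 to compound 4 (0.50 log units; beyond the scatter). In this assay compound 4 gives > 298000 nM, which is a limit of the assay and not a number. The direction therefore carries over between these two cores, but the size of the step on the second core stays unknown, so no equal or different transfer can be claimed: the same change on two cores in this assay, a 4.5-fold higher number (0.66 log units; beyond the scatter) from compound 1 to compound 2 and an at least 3.2-fold higher number (0.50 log units; beyond the scatter) from compound 3 to compound 4; the limit leaves it open whether they differ

The compounds shown carry only fluoro or hydrogen at this place, so it remains open how chloro or methoxy there would read on either core. On these data alone, whether the same direction holds on any core beyond these two also remains open.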